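This account rests on a few compounds, and the source may have more. Where it says the series, first, only, none or still open, it means among the compounds named here.

Measured in a functional assay (aorta) for antagonist activity, with Oryctolagus cuniculus as the target; on this read-out lower numbers stand for stronger inhibition and higher numbers for weaker inhibition:
compound 2 `CCCCc1ccc(CN(C(C)C)S(C)(=O)=O)c(=O)n1Cc1ccc(-c2ccccc2-c2nn[nH]n2)cc1` — 0.9 nM
compound 1 `CCCCc1ccc(CNC(C)=O)c(=O)n1Cc1ccc(-c2ccccc2-c2nn[nH]n2)cc1` — 3 nM

Among the measured compounds shown here, compound 2 gives the lowest of the two numbers; the one measured step, a 3.3-fold lower number from compound 1 to compound 2 (0.52 log units; beyond the scatter), is modest but beyond the scatter. Compound 3 `CCCCc1ccc(C)c(=O)n1Cc1ccc(-c2ccccc2-c2nn[nH]n2)cc1` carries the change (hydrogen in place of isopropyl(methylsulfonyl)amino on a saturated chain carbon bound to an aromatic carbon). For the measured compounds named here, no measured step removes this group outright; the step from compound 1 to compound 2 only swaps one such group for another, so it bears on compound 3 only loosely. A rise of roughly that size or somewhat more is therefore expected, an 8.9-fold higher number from compound 2 to compound 3 (0.95 log units; beyond the scatter). For compound 3 the estimate in this assay is 8 nM, expected to fall between 2 nM and 40 nM.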

Compound 3, half-maximal inhibitory concentration: 7 nM
The estimate for compound 3 lay 1.1-fold (0.06 log units) above the measured number; low and high end bracket the measured number.
By their numbers in this assay, from the lowest: compound 2; then compound 1; then compound 3.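

In this assay hydrogen on this saturated chain carbon gives a higher number than either group, with a 7.8-fold higher number from compound 2 to compound 3 (0.89 log units; beyond the scatter) and a 2.3-fold higher number from compound 1 to compound 3 (0.37 log units; beyond the scatter) as the two steps. Both groups thus lower the number relative to hydrogen, yet compound 3, with only a methyl there, still gives 7 nM and so neither group is required for activity. No evidence on the cause of these steps is at hand.

Open, going by these compounds, is how an amine, a carboxylic acid or a longer chain at this place would compare with isopropyl(methylsulfonyl)amino. Also open, on these data alone, is whether the isopropyl or the methylsulfonyl part accounts for the lower number of compound 2.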